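Swapping bromo for cyano on the benzoyl side

The compounds below may be only part of what the source reports. "The series", "measured", "known", "first", "only" and "open" are said of these compounds alone.

Measured in a functional assay on DU-145 cells (Homo sapiens) for inhibition, read by trypan blue exclusion, with a stated time of 96 h; on this read-out higher numbers stand for weaker inhibition of growth and lower numbers for stronger inhibition of growth:
- compound 1 `O=C(/C(=C\c1ccc(O)c([N+](=O)[O-])c1)SCc1ccc(Br)cc1)c1ccc(Br)cc1`: 10000 nM
- compound 2 `O=C(/C(=C\c1cc(I)c(O)c(I)c1)SCc1ccc(Br)cc1)c1ccc(Br)cc1`: 1000 nM
- compound 3 `COc1cc(/C=C(/SCc2ccc(Br)cc2)C(=O)c2ccc(Br)cc2)cc([N+](=O)[O-])c1O`: 25000 nM

Compound 1 holds the second highest of these three numbers. Its nearest neighbour lies at a 2.5-fold higher number from compound 1 to compound 3 (0.40 log units; beyond the scatter), and its furthest at a 10-fold lower number from compound 1 to compound 2 (1.00 log units; beyond the scatter).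

The next compound to be tested is compound 4 `N#Cc1ccc(C(=O)/C(=C\c2ccc(O)c([N+](=O)[O-])c2)SCc2ccc(Br)cc2)cc1`. It keeps the core of compound 1 and changes one group, 4-bromophenyl to 4-cyanophenyl: cyano in place of bromo on an aromatic carbon. The cyano group sits on an aromatic carbon, para to a large group.

Neither measured step touches the (4-bromophenyl)carbonyl group, so no measurement tests this change directly. Both steps were made in the hydroxyphenyl part, and they show only how far one substitution has moved the numbers in this small series. They give no direction for the new change, so no step beyond the scatter can be firmly predicted in this assay. The reading for compound 1 of 10000 nM is therefore the best anchor, with a margin as wide as the measured steps suggest.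

The estimate amounts to an expected no change at the digits printed from compound 1 to compound 4 (within the scatter).

For compound 4 the estimated value is 10000 nM, with an expected range of 3000 nM to 30000 nM.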

Compound 4, concentration for 50% growth inhibition: 10000 nM
The estimate for compound 4 equals the measured number at the digits printed, and the stated range covers the measured number.
By their numbers in this assay, from the lowest: compound 2; then compounds 1 and 4 (each within the scatter of the next); then compound 3.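

In this assay, replacing the 4-bromophenyl group with 4-cyanophenyl gives no change at the digits printed from compound 1 to compound 4 (within the scatter), and this is the only reading among these compounds that tests the (4-bromophenyl)carbonyl part of the molecule. At this aromatic carbon, para to a large group, bromo and cyano therefore cannot be told apart by this read-out, even though they differ in heavy atoms and cyano brings a hydrogen-bond acceptor, whereas the two substitutions in the hydroxyphenyl part gave a 10-fold lower number from compound 1 to compound 2 (1.00 log units; beyond the scatter) and a 2.5-fold higher number from compound 1 to compound 3 (0.40 log units; beyond the scatter). No supporting measurement is available to explain why the two groups read alike.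

Going by these compounds, it remains open whether this position would accept other groups equally well, such as an amine, a carboxylic acid or a longer alkyl chain. On these data alone, it is also open whether cyano in place of bromo would leave the number unchanged on the hydroxyphenyl pattern of compound 2 or compound 3, or whether the same swap on the other bromophenyl group, the one attached through sulfur, would do the same.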